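Cytotoxicity of Three Measured Analogues and a Fourth

The source may hold more compounds than are shown below. What is called first, only, known or untested is meant among the compounds shown, and "the series" means these compounds.

Compound 3 `Cn1nc(-c2nnc(-c3cccc(Br)c3)o2)c2ccccc21` gives > 100000 nM in an ADME assay on L02 cells (Homo sapiens) for cytotoxicity, read by MTT assay, with a stated time of 72 h (a higher number here means a weaker inhibitor, a lower number a stronger inhibitor), which is a limit of the assay rather than a number. Compound 1 `Cn1nc(-c2nnc(-c3cccc(Cl)c3)o2)c2ccccc21` gives only a limit as well in this assay, namely > 100000 nM. Compound 2 `Cc1ccc(-c2nnc(-c3nn(C)c4ccccc34)o2)cc1` likewise gives only a limit in this assay, > 100000 nM. All three values share (the limit of > 100000 nM in this assay, at which 3 of the 3 values shown sit), so the steps a step that the two limits leave unreadable from compound 1 to compound 2, a step that the two limits leave unreadable from compound 1 to compound 3 and a step that the two limits leave unreadable from compound 2 to compound 3 have no readable size. Compound 4 `Cn1nc(-c2nnc(-c3ccc(Cl)cc3)o2)c2ccccc21` differs from compound 3 by 4-chlorophenyl in place of 3-bromophenyl on an aromatic carbon. Going by the values given here, with no measured step readable in this assay, no shift beyond the scatter is expected for compound 4. Compound 4 is estimated at 150000 nM in this assay, with a range from 60000 nM to 500000 nM. The expected step is a step that the limit leaves unreadable from compound 3 to compound 4.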

Compound 4, half-maximal inhibitory concentration: > 100000 nM
Compound 4 gave a limit, no number; the forecaster's own chance of this, stated with the estimate: 85%; the middle value is on the limit's open side.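

Going by these compounds alone, compound 4 gives only a limit, so no step among compound 1, compound 2, compound 3 and compound 4 can be read: the limit of > 100000 nM in this assay, at which 4 of the 4 values shown sit.
In this assay the compounds shown leave open whether any change on the shared core would give a measurable value.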